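Methyl for methoxycarbonyl: from compound 2 to compound 3

A few compounds are considered here, and "the series" means these few. Any claim that something is new, unique, unknown or untested is made for them only; others in the source may bear on it.

Measured so far in a functional assay on Vero cells (Chlorocebus sabaeus) for inhibition (on this read-out lower numbers stand for stronger inhibition and higher numbers for weaker inhibition), are two compounds:
Compound 1 `COc1cc(/C=C/C(=O)c2cccc(NC(=O)c3ccco3)c2)ccc1O` with 3.11 ug/mL
Compound 2 `COC(=O)C(=O)Nc1cccc(C(=O)/C=C/c2ccc(O)c(OC)c2)c1` with 3.55 ug/mL

Compound 2 stands at 3.55 ug/mL on this read-out, which lies within the scatter of compound 1 at 3.11 ug/mL in the same measurement. Compound 3 `COc1cc(/C=C/C(=O)c2cccc(NC(C)=O)c2)ccc1O` is still unmeasured. It carries methyl in place of methoxycarbonyl on a carbonyl carbon whose other neighbours are an amide-type nitrogen, and the change counts as methyl in place of methoxycarbonyl on a carbonyl carbon in full. Within the data shown here, one measured step bears on this place, namely a 1.1-fold higher number from compound 1 to compound 2 (0.06 log units; within the scatter) for methoxycarbonyl in place of furan-2-yl. That step stayed within the scatter. Among the measured compounds shown here, it is a single step, however, and no measured compound yet carries methyl there. No step beyond the scatter is therefore expected in this assay and no direction is favoured. The expected change is a 1.1-fold lower number from compound 2 to compound 3 (0.03 log units; within the scatter) in this estimate. Compound 3 is estimated at 3.3 ug/mL with an expected range from 1.5 ug/mL to 7.5 ug/mL in this measurement.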

Compound 3, half-maximal inhibitory concentration: 14.5 ug/mL
Compound 3: the middle estimate sits 4.4-fold (0.64 log units) below what was measured; measured number outside the range, above it.
By their numbers in this assay, from the lowest: compounds 1 and 2 (each within the scatter of the next); then compound 3.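

In this assay, the group on the carbonyl carbon whose other neighbour is an amide-type nitrogen now proves not to be interchangeable: methyl in place of methoxycarbonyl gives a 4.1-fold higher number from compound 2 to compound 3 (0.61 log units; beyond the scatter), and methyl in place of furan-2-yl gives a 4.7-fold higher number from compound 1 to compound 3 (0.67 log units; beyond the scatter). The earlier pair showed only that furan-2-yl and methoxycarbonyl could be exchanged within the scatter, which left open whether this place responds to a change of group at all; with methyl, both steps point the same way, towards weaker inhibition, and neither of the other two groups goes against this among the three compounds. Nothing given here accounts for why methyl parts from the other two groups.

The three compounds leave open whether the weaker inhibition belongs to methyl alone, or whether a longer chain such as ethyl or propyl, a phenyl ring, or an amine on that carbonyl carbon would stand with compound 3 or with compound 1 and compound 2. They also do not show what happens when the whole acetamido group gives way to a plain amino group.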